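The compounds below may be only part of what the source reports. "The series", "measured", "known", "first", "only" and "open" are said of these compounds alone.

Compound 1 `C#CCN(CCCCOc1ccc2ccc(=O)oc2c1)Cc1cccc(F)c1` gives 1550 nM
Compound 2 `C#CCN(C)CCCOc1ccc2ccc(=O)oc2c1` gives 1090 nM
Compound 3 `C#CCN(CCCOc1ccc2ccc(=O)oc2c1)Cc1ccccc1` gives 3740 nM

In an assay on isolated protein for inhibition of Amine oxidase [flavin-containing] B (Homo sapiens), read by fluorescence and Amplex Red, with stated times of 15 min and 20 min (a higher number here means a weaker inhibitor, a lower number a stronger inhibitor), compound 1 stands second highest of the three numbers. Its nearest neighbour is compound 2, whose value is within the scatter of it, so the two are not separable; compound 3 gives a higher number than compound 1, beyond the scatter. Compound 4 `C#CCN(CCCCOc1ccc2ccc(=O)oc2c1)Cc1ccc(F)c(F)c1` is not yet measured. It differs from compound 1 by fluoro in place of hydrogen on an aromatic carbon. For the measured compounds named here, the one measured step between single-point neighbours, a 3.4-fold higher number from compound 2 to compound 3 (0.54 log units; beyond the scatter), concerns a phenyl added on the chain carbon bound to the amine nitrogen and does not touch an aromatic fluoro; no measured step covers a fluoro added to the benzyl ring. With nothing in the data bearing directly on this change, the expected step from compound 1 to compound 4 is a 1.1-fold lower number from compound 1 to compound 4 (0.04 log units; within the scatter), none beyond the scatter. Compound 4 is therefore estimated at 1400 nM, within 600 nM to 3500 nM.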

Compound 4, half-maximal inhibitory concentration: 2370 nM
The estimate for compound 4 lay 1.7-fold (0.23 log units) below the measured number, within the range that was stated.
By their numbers in this assay, from the lowest: compounds 2, 1, 4 and 3 (each within the scatter of the next, the first and the last beyond it).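

In this assay, for the compounds shown here, going from 3-fluorophenyl to 3,4-difluorophenyl gives a 1.5-fold higher number from compound 1 to compound 4 (0.18 log units; within the scatter), the first reading of a change on this aromatic ring. As far as this single pair goes, a fluoro at this place, ortho to a fluoro group and para to a large group, leaves compound 4 not separable from compound 1. Nothing available gives a reason for this outcome.

Going by these compounds, whether this place would accept a larger group such as chloro, methoxy or trifluoromethyl in the same way remains open. Also open, on these data alone, is how a fluoro at this place would read without the existing fluoro group, and whether the result carries over to a shorter chain between the amine and the core.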